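From compound 2 to compound 4: methoxy for hydrogen

A few compounds are considered here, and "the series" means these few. Any claim that something is new, unique, unknown or untested is made for them only; others in the source may bear on it.

In a functional assay on PC-3 cells (Homo sapiens) for cytotoxicity, read by WST assay, with a stated time of 24 h (a lower number here means a stronger inhibitor, a higher number a weaker inhibitor), compound 2 `N#C/C(=C\c1c[nH]c2cc(F)ccc12)C(=O)c1c[nH]c2ccccc12` gives > 50000 nM, which is a limit and not a number. Compound 1 `N#C/C(=C\c1c[nH]c2cc(F)ccc12)C(=O)c1c[nH]c2cc(F)ccc12` gives > 50000 nM, also a limit. Among the measured compounds shown here, compound 3 `COc1ccc2c(/C=C(\C#N)C(=O)c3c[nH]c4ccccc34)c[nH]c2c1` gives 33300 nM, the only true number so far. Overall, the series shows (the limit of > 50000 nM in this assay, at which 2 of the 3 values shown sit).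

Compound 4 `COc1ccc2[nH]cc(C(=O)/C(C#N)=C/c3c[nH]c4cc(F)ccc34)c2c1` differs from compound 2 by methoxy in place of hydrogen on an aromatic carbon. For the measured compounds named here, two measured steps bear on this change. The exchange of fluoro for hydrogen offers only a step that the two limits leave unreadable from compound 1 to compound 2. The closest guide is an at least 1.5-fold lower number from compound 2 to compound 3 (0.17 log units; that floor lies within the scatter), although there methoxy replaces fluoro, not hydrogen. Going by the values given here, no measured step therefore shows a change beyond the scatter, and none places methoxy where compound 4 carries it.

An estimated at least 1.1-fold lower number from compound 2 to compound 4 (0.04 log units; that floor lies within the scatter) is expected, which would be a small move towards a lower number in this assay, if any. A reading at the limit would also fit this expectation. For compound 4 the expected value is 45000 nM, with an estimated range of 20000 nM to 100000 nM.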

Compound 4, half-maximal inhibitory concentration: > 50000 nM
Compound 4 gave a limit, no number (the forecaster's own chance of this, stated with the estimate: 60%); at least 1.1-fold (0.04 log units) between middle value and limit.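

In this assay compound 4 gives > 50000 nM, a limit and not a number. Among the compounds shown here, compound 2 also stands at a limit, so no step between compound 2 and compound 4 can be read. As far as these compounds go, whether methoxy in place of hydrogen on this aromatic carbon changes the value at all remains open.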